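Weak Cytotoxicity and a 2-Methylphenyl Substituent

The source may report more compounds than this note shows. Statements on the series, on what has been measured and on what is new or still open speak of the compounds shown alone.

The shared core carries a primary amide and an amino group; compound 1 `NC(=O)c1cn(Cc2ccccc2)c2ncnc(N)c12` bears a phenyl on a saturated chain carbon bound to an aromatic nitrogen. In a functional assay on KB cells (Homo sapiens) for cytotoxicity (a lower number here means a stronger inhibitor, a higher number a weaker inhibitor), compound 1 gives 75000 nM. Compound 2 `Cc1cccc(Cn2cc(C(N)=O)c3c(N)ncnc32)c1` has a methyl in place of hydrogen on an aromatic carbon of that phenyl. In this assay compound 2 gives > 100000 nM, which is a limit of the assay rather than a number. Compound 3 `Cn1cc(C(N)=O)c2c(N)ncnc21` has hydrogen in place of phenyl. In this assay compound 3 gives > 100000 nM, again a limit of the assay. Compound 3 thus stands only at the limit of > 100000 nM in this assay, at which 2 of the 3 values shown sit.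

Compound 4 `Cc1ccccc1Cn1cc(C(N)=O)c2c(N)ncnc21` differs from compound 3 by 2-methylphenyl in place of hydrogen on a saturated chain carbon bound to an aromatic nitrogen. For the measured compounds named here, two measured steps bear on this change: an at least 1.3-fold higher number from compound 1 to compound 3 (0.12 log units; that floor lies within the scatter) and an at least 1.3-fold higher number from compound 1 to compound 2 (0.12 log units; that floor lies within the scatter). Both are floors that lie within the scatter, so neither restoring the phenyl nor adding a methyl to it has shown a readable effect, and the step that the two limits leave unreadable from compound 2 to compound 3 adds nothing readable. Compound 4 is therefore expected to remain near the limit. The step of a number no higher from compound 3 to compound 4 (the limit leaves the size open) is expected to stay within the scatter. For compound 4 in this assay the estimate is 100000 nM, with a range from 40000 nM to 300000 nM.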

Compound 4, half-maximal inhibitory concentration: > 100000 nM
Compound 4 gave a limit, no number; the forecaster's own chance of this, stated with the estimate: 60%; the middle value sits exactly at the limit.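

The 2-methylphenyl group of compound 4 gives no readable value in this assay, so this position has now reached the same limit with hydrogen, 3-methylphenyl and 2-methylphenyl: the limit of > 100000 nM in this assay, at which 3 of the 4 values shown sit. The one step that can be read is an at least 1.3-fold higher number from compound 1 to compound 4 (0.12 log units; that floor lies within the scatter), so a methyl on the phenyl has shown no change beyond the scatter, in either of the two places tested. The steps to compound 4 from compound 2 and from compound 3 cannot be read, as each joins two limits. Plain phenyl in compound 1 remains the only group at this position with a measured number, at 75000 nM.

Going by these compounds, how far compounds 2, 3 and 4 lie past their shared limit stays open, so the order among them is unknown. Also open, on these data alone, is whether an amine or a carboxylic acid on the phenyl, or a longer chain in place of the single saturated chain carbon, would bring the number down to a clearly lower value in this assay.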